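A few compounds are considered here, and "the series" means these few. Any claim that something is new, unique, unknown or untested is made for them only; others in the source may bear on it.

Measured compounds in a functional assay on HEK293 cells with D(4) dopamine receptor (Homo sapiens) as the target, read by FLIPR; on this read-out higher numbers stand for larger maximal responses and lower numbers for smaller maximal responses:
compound 1 `O/N=C(/CCN1CCN(c2ccccn2)CC1)c1ccccc1` gives 74%
compound 2 `Cc1ccccc1/C(CCN1CCN(c2ccccn2)CC1)=N/O` gives 82%

Among the compounds with values here, compound 2 holds the highest of the two numbers, yet its only neighbour, compound 1, lies a few points under it and the two fall within the scatter of this assay, so neither can be called the larger response. The next compound, compound 3 `Cc1ccccc1/C(CCN1CCN(c2ccccn2)CC1)=N\O`, keeps every atom and bond of compound 2, and the difference is confined to geometry: the two compounds have the same atoms and bonds and differ only in configuration as drawn: 1 of 1 stereo elements differ; a double bond is drawn E in compound 2 and Z in compound 3.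

Within the data shown here, no step between two measured compounds exists here, so there is no measured case to lean on for how a change of this kind plays out in this assay. With no such guide, the expected step from compound 2 to compound 3 is small, with no firm direction, and the width of the range must carry the uncertainty. Compound 3 is expected to give 75% in this assay, with a range from 50% to 95%, which means an estimated step of a number 7 percentage points lower from compound 2 to compound 3 (within the scatter).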

Compound 3, largest response reached (reported as efficacy), in percent of the reference or control that the assay uses: 72%
Beside the measured number, compound 3's estimate is 3 percentage points above it; low and high end bracket the measured number.
By their numbers in this assay, from the lowest: compounds 3, 1 and 2 (each within the scatter of the next).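

In this assay, the double bond now has its first measured step for a change of geometry alone, E to Z, with a number 10 percentage points lower from compound 2 to compound 3 (within the scatter), so the drawn configuration shows no effect here that can be told from the scatter. The same holds for methyl in place of hydrogen on an aromatic carbon, which comes with a number 2 percentage points lower from compound 1 to compound 3 (within the scatter). The first comparison isolates geometry, because nothing else separates that pair: the fact that compounds 2 and 3 differ only in the configuration as drawn.

The compounds shown leave open whether the double-bond geometry would matter more with an ethyl group, a chlorine atom or a methoxy group in place of that methyl. They also leave open what a methyl ether on the oxime oxygen would do to the maximal response.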